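Shortening the chain on the imine nitrogen of compound 1

The source may hold more compounds than are shown below. What is called first, only, known or untested is meant among the compounds shown, and "the series" means these compounds.

Going by the values given here, compound 1 `CCCC/N=C(\NC#N)Nc1cccnc1` holds the only plain number in a functional assay on the whole organism (blood, strain Wistar-Okamoto) with Rattus norvegicus as the target, with a stated time of 5 days; a lower number here means that less compound is needed, a higher number that more compound is needed for the effect; compound 1 gives 20 mg/kg. Compound 2 `CCCCCCC/N=C(\NC#N)Nc1cccnc1` reaches only a limit of the assay, > 50 mg/kg, and sits at the limit of > 50 mg/kg in this assay, at which 1 of the 2 values shown sits. Among the compounds with values here, the step of an at least 2.5-fold higher number from compound 1 to compound 2 (0.39 log units; beyond the scatter) is the single measured comparison. Compound 3 `CC(C)/N=C(\NC#N)Nc1cccnc1` differs from compound 1 by isopropyl in place of butyl on a double-bonded nitrogen. The measured step added propyl to the chain, so it bears on compound 3 only loosely; for a shorter branched group no step beyond the scatter is expected, the expected step being no change at the digits printed from compound 1 to compound 3 (within the scatter). Compound 3 is therefore estimated at 20 mg/kg, within 8 mg/kg to 50 mg/kg.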

Compound 3, minimum effective dose: 2.5 mg/kg
For compound 3 the middle estimate is 8.0-fold (0.90 log units) above the measured one; the whole stated range lies above it.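

Isopropyl in place of butyl on a double-bonded nitrogen gives an 8.0-fold lower number from compound 1 to compound 3 (0.90 log units; beyond the scatter) in this assay, so this position also admits a change that lowers the dose needed. The earlier step, an at least 2.5-fold higher number from compound 1 to compound 2 (0.39 log units; beyond the scatter), showed only a rise with the longer chain. Nothing measured here gives a cause for the new step.

Compound 3 shortens and branches the chain in one change, so the two cannot be told apart. Straight propyl, tert-butyl and cyclopropyl at this place are absent from the compounds shown.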